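Working notes on a positive allosteric modulator series, compound 4 pending

A few compounds are considered here, and "the series" means these few. Any claim that something is new, unique, unknown or untested is made for them only; others in the source may bear on it.

compound 1 `O=C(N1CCC(F)CC1)N1CC(c2nc(-c3cccc(Cl)c3)no2)C1` — in an assay on HEK293 cells for positive allosteric modulation of metabotropic glutamate receptor 5 (Homo sapiens), read by FLIPR (on this read-out lower numbers stand for an effect already at smaller amounts and higher numbers for an effect only at larger amounts of compound), compound 1 gives 990 nM
compound 2 `Cc1ccc(C(=O)N2CC(c3nc(-c4cccc(F)c4)no3)C2)cc1` — compound 2 gives 6800 nM
compound 3 `Cc1cccc(-c2noc(C3CN(C(=O)c4ccccc4F)C3)n2)c1` — for compound 3 the assay reports only a limit, > 10000 nM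

Among the numbers available, compound 1 stands lowest; compound 2 gives a clearly higher number, and the gap between the two lies beyond the usual scatter. The reading for compound 3 is a limit of the assay and not a number, as noted in the limit of > 10000 nM in this assay, at which 1 of the 3 values shown sits. Compound 1, a urea bearing a saturated ring, is thus the reference point of the set, while the two aryl amides, compound 2 and compound 3, sit weaker or at the limit.

Compound 4 `COC1CCCN(C(=O)N2CC(c3nc(-c4cccc(Cl)c4)no3)C2)C1` has not yet been measured. It differs from compound 1 in one place: 3-methoxypiperidin-1-yl in place of 4-fluoropiperidin-1-yl on a carbonyl carbon. Among the compounds with values here, no two measured compounds differ by a change of this kind, so the size of the step can only be guessed. The expected step of a 1.5-fold higher number from compound 1 to compound 4 (0.18 log units; within the scatter) is small, if anything towards a somewhat higher number, and may well stay within the scatter. Compound 4 is accordingly expected near 1500 nM, with a likely range of 500 nM to 5000 nM.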

Compound 4, half-maximal effective concentration: > 10000 nM
Compound 4: only a limit was reported; the forecaster's own chance of this, stated with the estimate: 10%; middle value at least 6.6-fold (0.82 log units) from the limit.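

In this assay, exchanging the group on the carbonyl carbon, with 4-fluoropiperidin-1-yl leaving and 3-methoxypiperidin-1-yl entering, gives an at least 10-fold higher number from compound 1 to compound 4 (1.00 log units; beyond the scatter), the first one-place step measured in this set. This position therefore does not accept every six-membered non-aromatic ring equally, and a change of one substituted ring for another on the same carbonyl carbon is enough to take the series from a measurable number to the top of the range. The reading for compound 4 is a limit of the assay and not a number, so the step has a lower bound only, and the reading adds to those that end at the limit: the limit of > 10000 nM in this assay, at which 2 of the 4 values shown sit.

One pair cannot separate the arrival of the methoxy group from the loss of the fluorine, nor either of these from the place of the substituent on the ring. Also open, from the compounds shown here alone, is how a plain piperidine, a morpholine or a small open-chain amine such as dimethylamine would read on the same carbonyl carbon, with the rest of compound 1 kept unchanged.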